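Cytotoxicity notes: varying the amine side chain

The source may hold more compounds than are shown below. What is called first, only, known or untested is meant among the compounds shown, and "the series" means these compounds.

Measured so far:
compound 1 `CCCNc1nc(C)c(-c2nc3ccccc3s2)c(N[C@@H]2C[C@H](CO)[C@@H](O)[C@H]2O)n1`, in an ADME assay on cells (Homo sapiens) for cytotoxicity, read by polymerase chain reaction, with a stated time of 3 days (a higher number here means that more compound is tolerated, a lower number that less compound is tolerated), gives > 25000 nM
compound 2 `Cc1nc(NCC2CC2)nc(N[C@@H]2C[C@H](CO)[C@@H](O)[C@H]2O)c1-c1nc2ccccc2s1`, in this assay gives 8000 nM

The value for compound 1 is a limit of this assay, not a number. Compound 2 therefore holds the only number shown, and the one measured step, an at least 3.1-fold lower number from compound 1 to compound 2 (0.49 log units; beyond the scatter), rests on (the limit of > 25000 nM in this assay, at which 1 of the 2 values shown sits).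

Compound 3 `CCOCCNc1nc(C)c(-c2nc3ccccc3s2)c(N[C@@H]2C[C@H](CO)[C@@H](O)[C@H]2O)n1` carries ethoxymethyl in place of cyclopropyl on a saturated chain carbon bound to a nitrogen on an aromatic ring. The measured step bears on this only in part: there a chain end became the cyclopropyl and the number fell beyond the scatter; here the cyclopropyl leaves again for a chain carrying one oxygen. Among the measured compounds shown here, on that basis the number is expected to move back up rather than down, though the size is uncertain since only one step is available. Compound 3 is estimated at 15000 nM, between 5000 nM and 40000 nM. The expected step is a 1.9-fold higher number from compound 2 to compound 3 (0.27 log units; within the scatter), with a fair chance that this assay again reports only a limit.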

Compound 3, half-maximal cytotoxic concentration: 18000 nM
Estimate against measurement, compound 3: 1.2-fold (0.08 log units) below; measured number inside the range.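

The change from cyclopropyl to ethoxymethyl gives a 2.3-fold higher number from compound 2 to compound 3 (0.35 log units; beyond the scatter) in this assay. Among the compounds shown here, this is the only step that joins two numbers, so the effect of the ring at this position no longer rests on the step from compound 1 alone. Ethoxy in place of methyl gives an at least 1.3-fold lower number from compound 1 to compound 3 (0.14 log units; that floor lies within the scatter), so compound 1 and compound 3 cannot be ordered, and the value of compound 1 is a limit: the limit of > 25000 nM in this assay, at which 1 of the 3 values shown sits.

For the compounds shown here, compound 2 is the only ring-bearing compound here, so it remains open whether the lower number belongs to cyclopropyl specifically or would recur with a cyclobutyl ring. Going by these compounds, how a longer alkyl chain, or a hydroxyl or dimethylamine at the chain end, would compare in this assay also remains open.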